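This account rests on a few compounds, and the source may have more. Where it says the series, first, only, none or still open, it means among the compounds named here.

Measured in a functional assay on NALM-6 cells (Homo sapiens) for cytotoxicity, with a stated time of 72 h; a lower number here means that less compound is needed, a higher number that more compound is needed for the effect:

Compound 1 `C=C[C@@](C)(/C=C/c1ccc(OS(=O)(=O)C(F)(F)F)cc1)CCC=C(C)C`: > 43400 nM, a limit.
Compound 2 `C=C[C@@](C)(/C=C/c1ccc(O)cc1)CCC(O)C(C)(C)O`: > 43400 nM, a limit.
Compound 3 `C=C[C@@](C)(/C=C/c1ccc(O)cc1)CCCO`: > 43400 nM, a limit.

All three results are limits and none is a number: the limit of > 43400 nM in this assay, at which 3 of the 3 values shown sit. Compound 3 therefore stands only at a limit, alongside the other two. Compound 4 `C=C[C@@](C)(/C=C/c1ccc(O)cc1)CC/C=C(\C)C=O` carries 2-formylprop-1-en-1-yl in place of hydroxymethyl on a saturated chain carbon, three bonds along the chain from two double-bonded chain carbons. Within the data shown here, the one measured step, a step that the two limits leave unreadable from compound 2 to compound 3, has no readable size, so no measured step sizes this change. A modest move toward less compound needed is tentatively expected, with the estimated step being an at least 1.4-fold lower number from compound 3 to compound 4 (0.16 log units; that floor lies within the scatter), though compound 4 may equally be reported only as a limit. Compound 4 is estimated at 30000 nM, with an expected range from 8000 nM to 80000 nM.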

Compound 4, half-maximal effective concentration: 12600 nM
Compound 4: middle estimate off by 2.4-fold (0.38 log units), on the high side; measured number inside the range.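

In this assay, compound 4 alone among the compounds shown gives a number rather than a limit: the limit of > 43400 nM in this assay, at which 3 of the 4 values shown sit.

Setting 2-formylprop-1-en-1-yl in place of hydroxymethyl gives an at least 3.4-fold lower number from compound 3 to compound 4 (0.53 log units; beyond the scatter), so this position does respond to the group it carries. Setting it in place of 1,2-dihydroxy-2-methylpropyl gives an at least 3.4-fold lower number from compound 2 to compound 4 (0.53 log units; beyond the scatter), and both steps are floors on the true size.

Whether the formyl group, the double bond or the longer chain accounts for these steps stays open. So does the effect of a carboxylic acid or an amine at this place.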